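The source may hold more compounds than are shown below. What is called first, only, known or untested is meant among the compounds shown, and "the series" means these compounds.

Working notes on a small set of triazole-thione sulfides built on one shared core. Compound 1 `CCOc1ccc(-n2c(S)nnc2CSc2nnc(-c3ccccc3)n2-c2ccccc2)cc1` and compound 3 `CC(C)n1c(S)nnc1CSc1nnc(-c2ccccc2)n1-c1ccccc1` belong to the set but carry no result in a functional assay on MDA-MB-231 cells (Homo sapiens) for inhibition, read by MTT assay, with a stated time of 48 h; a lower number here means a stronger inhibitor, a higher number a weaker inhibitor: for compound 1 the entry reads "not determined" (no result reported), and for compound 3 the entry reads "not determined" (no result reported). Within the data shown here, compound 2 `Fc1ccc(-n2c(S)nnc2Sc2nnc(-c3ccccc3)n2-c2ccccc2)cc1` is the only member with a number: in this assay compound 2 gives 29700 nM, which places it as a weak inhibitor and, being the sole value, gives no comparison within the set.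

The next member, compound 4 `CCOc1ccc(-n2c(S)nnc2Sc2nnc(-c3ccccc3)n2-c2ccccc2)cc1`, is not yet measured. It differs from compound 2 in one place only: ethoxy in place of fluoro on an aromatic carbon, para to a large group on the phenyl attached to the triazole nitrogen. Among the measured compounds shown here, no pair of measured compounds shows what this kind of change does on this core, so there is no measured step to lean on.

With only compound 2 as anchor, the expectation is a step of a 1.2-fold higher number from compound 2 to compound 4 (0.07 log units; within the scatter) that stays within the usual scatter, with no clear direction; compound 4 is estimated at 35000 nM, expected to lie between 12000 nM and 100000 nM, and it remains possible that this assay reports only a limit for it.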

Compound 4, half-maximal inhibitory concentration: 43900 nM
For compound 4 the middle estimate is 1.3-fold (0.10 log units) below the measured one; measured number inside the range.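

In this assay, among these compounds, the first readable step on the shared core, 4-fluorophenyl to 4-ethoxyphenyl, gives a 1.5-fold higher number from compound 2 to compound 4 (0.17 log units; within the scatter). This position therefore takes ethoxy, with 3 heavy atoms and 1 hydrogen-bond acceptor, in place of fluoro, with 1 heavy atom and no hydrogen-bond acceptor, and the two values cannot be told apart; on this single pair, the exchange leaves the number in the same weak range. No supporting measurement is available to explain this result.

On these data alone, whether an amine, a carboxylic acid or a chain longer than ethoxy at this position would give a step beyond the scatter remains open, and a single pair cannot show whether the result would hold for other groups. The compounds shown also leave open whether a similar exchange elsewhere on the shared core, such as on either of the unsubstituted phenyl rings, would give a step of similar size.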